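Swapping the dipropylamino arm for neopentylamino

The source may hold more compounds than are shown below. What is called first, only, known or untested is meant among the compounds shown, and "the series" means these compounds.

Compound 1 `CCCN(CCC)c1c(C)nc(-c2c(C)cc(C)cc2OC)nc1OC` is the stronger of the two measured compounds: in an in vitro assay on IMR-32 cells for displacement of a labelled ligand from corticotropin-releasing factor receptor 1 (Homo sapiens) (a lower number here means a stronger inhibitor, a higher number a weaker inhibitor), compound 1 gives 15 nM, while compound 2 `CCCN(CCC)c1c(CC(C)O)nc(-c2c(C)cc(C)cc2OC)nc1OC` gives 1150 nM. Among the measured compounds shown here, the one measured step, a 77-fold higher number from compound 1 to compound 2 (1.88 log units; beyond the scatter), concerns a change at a different place and so bears only loosely on what follows. Compound 3 `COc1cc(C)cc(C)c1-c1nc(C)c(NCC(C)(C)C)c(OC)n1` differs from compound 1 by neopentylamino in place of dipropylamino on an aromatic carbon. For the measured compounds named here, no measured step covers this kind of change, so the expectation is a modest weakening, a 2.7-fold higher number from compound 1 to compound 3 (0.43 log units; beyond the scatter), with wide uncertainty. Compound 3 is estimated at 40 nM, within a range from 8 nM to 200 nM.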

Compound 3, inhibition constant: > 10000 nM
Compound 3 gave a limit, no number (the forecaster's own chance of this, stated with the estimate: 5%); at least 250-fold (2.39 log units) between middle value and limit.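

In this assay, this position on the aromatic carbon proves highly sensitive to the choice of amine arm: neopentylamino in place of dipropylamino gives an at least 660-fold higher number from compound 1 to compound 3 (2.82 log units; beyond the scatter). The arms are close in size, at 7 and 6 heavy atoms, yet only neopentylamino carries a hydrogen-bond donor. Compound 3 gives a limit of the assay, not a number: the limit of > 10000 nM in this assay, at which 1 of the 3 values shown sits.

The compounds shown cannot separate the effect of that donor from the effect of the changed carbon framework. Also open, from the compounds shown here alone, is how arms such as dibutylamino or propylamino would compare.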